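Swapping a phenyl for a chloromethyl on the carbonyl

The source may hold more compounds than are shown below. What is called first, only, known or untested is meant among the compounds shown, and "the series" means these compounds.

Compound 1, `CC1=NN(C(=O)c2ccc([N+](=O)[O-])cc2)C(c2ccccc2O)C1`: 36600 nM
Compound 2, `CC1=NN(S(=O)(=O)c2ccc(C)cc2)C(c2cc(Br)ccc2O)C1`: 33200 nM
Compound 3, `O=C(c1ccccc1)N1N=C(c2cc3ccccc3oc2=O)CC1c1ccccc1`: 5870 nM

Of the compounds shown here, three have been measured in a functional assay on PC-3 cells (Homo sapiens) for cytotoxicity, read by MTT assay, with a stated time of 48 h; on this read-out lower numbers stand for stronger inhibition and higher numbers for weaker inhibition. Compound 3 gives 5870 nM, the lowest of the three numbers; compound 2, the nearest, and compound 1 both sit well beyond the scatter above it, so compound 3 is the strongest inhibitor among the measured set.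

Compound 4, `O=C(CCl)N1N=C(c2cc3ccccc3oc2=O)CC1c1ccccc1`, differs from compound 3 in one place: chloromethyl in place of phenyl on a carbonyl carbon. Among the measured compounds shown here, no pair of measured compounds shows this kind of change, so its effect on the numbers is unknown. The expectation is a step of modest size, more likely toward a lower number than a higher one, though a result within the scatter of compound 3 would not be surprising. Compound 4 is therefore expected to give about 3500 nM, with a range from 800 nM to 15000 nM. The implied step a 1.7-fold lower number from compound 3 to compound 4 (0.22 log units; within the scatter) is expected to stay small, and a measurement will decide whether it holds.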

Compound 4, half-maximal inhibitory concentration: 2980 nM
Estimate against measurement, compound 4: 1.2-fold (0.07 log units) above; the range from low to high includes it.
By their numbers in this assay, from the lowest: compounds 4 and 3 (each within the scatter of the next); then compounds 2 and 1 (each within the scatter of the next).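

In this assay, exchanging phenyl for chloromethyl on the carbonyl carbon gives a 2.0-fold lower number from compound 3 to compound 4 (0.29 log units; within the scatter). Among the compounds shown here, this is the first direct look at this position, and it shows that the aromatic ring of the benzoyl group can be replaced by a chain with far fewer heavy atoms, with no ring at all, while the number stays within the usual scatter. Nothing measured here explains why the two compounds read alike.

On these data alone, what the chlorine contributes remains open, since a plain methyl, an aminomethyl or a longer chain such as chloroethyl on the same carbonyl carbon would separate the chlorine from the size of the group. It is also unknown whether this swap would read the same way on the cores of compound 1 and compound 2.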